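Unmasking a Dimethoxyphenyl Ether: Methyl Groups Off, Hydroxyls On

This account rests on a few compounds, and the source may have more. Where it says the series, first, only, none or still open, it means among the compounds named here.

Four compounds are in view, and the measure of each is a functional assay on RS4-11 cells (Homo sapiens) for inhibition, read by CCK-8 assay, with a stated time of 48 h; a lower number here means a stronger inhibitor, a higher number a weaker inhibitor. Compound 1 `O=C(Nc1cccc([N+](=O)[O-])c1)N1CCN(S(=O)(=O)c2sccc2-c2ccccc2Oc2ccc(O)c(O)c2)CC1` gives 9800 nM in this assay. Compound 2 `COc1ccc(Oc2ccccc2-c2ccsc2S(=O)(=O)N2CCN(C(=O)Nc3cccc([N+](=O)[O-])c3)CC2)cc1OC` gives > 50000 nM in this assay, which is a limit of the assay rather than a number. Compound 2 sits at the limit of > 50000 nM in this assay, at which 1 of the 3 values shown sits. The change from compound 2 to compound 1 is 3,4-dihydroxyphenyl in place of 3,4-dimethoxyphenyl on an oxygen on an aromatic ring, and it produced an at least 5.1-fold lower number from compound 2 to compound 1 (0.70 log units; beyond the scatter).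

Compound 3 `COc1ccc(Oc2ccc(C(C)C)cc2-c2ccsc2S(=O)(=O)NCCNC(=S)Nc2cc(C(F)(F)F)cc(C(F)(F)F)c2)cc1OC` carries a different core; the difference between the two cores is not broken down here. In this assay, going by the values given here, compound 3 gives 5500 nM, a value within the scatter of the one for compound 1.

Compound 4 `CC(C)c1ccc(Oc2ccc(O)c(O)c2)c(-c2ccsc2S(=O)(=O)NCCNC(=S)Nc2cc(C(F)(F)F)cc(C(F)(F)F)c2)c1` has not yet been measured. Among the compounds with values here, it differs from compound 3 by 3,4-dihydroxyphenyl in place of 3,4-dimethoxyphenyl on an oxygen on an aromatic ring, the same change as the one from compound 2 to compound 1, made at the same place. Because that change gave an at least 5.1-fold lower number from compound 2 to compound 1 (0.70 log units; beyond the scatter), compound 4 is expected to return a lower number than compound 3, with an expected step of a 3.7-fold lower number from compound 3 to compound 4 (0.56 log units; beyond the scatter). The estimate for compound 4 in this assay is 1500 nM, expected to fall between 400 nM and 5000 nM.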

Compound 4, half-maximal inhibitory concentration: 3700 nM
Estimate against measurement, compound 4: 2.5-fold (0.39 log units) below; low and high end bracket the measured number.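

On the core of compound 3, putting 3,4-dihydroxyphenyl in place of 3,4-dimethoxyphenyl gives a 1.5-fold lower number from compound 3 to compound 4 (0.17 log units; within the scatter) in this assay and this step cannot be told apart from repeat measurement. The change therefore does not carry over at the same size from the core of compound 1 to the core of compound 4: the same change on two cores in this assay, an at least 5.1-fold lower number (0.70 log units; beyond the scatter) from compound 2 to compound 1 and a 1.5-fold lower number (0.17 log units; within the scatter) from compound 3 to compound 4, at least 3.4-fold (0.53 log units) apart, beyond the scatter of two such steps. As far as these compounds go, compound 2 stands at > 50000 nM which is a limit of the assay and not a number, and the full size of the first step stays unknown; two cores also cannot show how the change would behave on a third core.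

The compounds shown leave open which of the differences between the two cores sets the gap between the two steps. Also open, from the compounds shown here alone, is whether a phenyl ring carrying a single hydroxyl, or one carrying an amine or a carboxylic acid instead, would give a lower number on either core.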